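Efficacy of an aryl amide swap at the carbonyl

This account rests on a few compounds, and the source may have more. Where it says the series, first, only, none or still open, it means among the compounds named here.

The series shares the core of compound 1, `COc1ccc(C(=O)NC(CCN(C)C)c2ccc(Cl)cc2)cc1`, an amide whose aromatic acyl group is varied. In an assay on NIH3T3 cells with Urotensin-2 receptor (Homo sapiens) as the target (on this read-out higher numbers stand for larger maximal responses and lower numbers for smaller maximal responses), compound 1 gives 162%, the highest of the two numbers measured; its nearest neighbour is compound 2, `CN(C)CCC(NC(=O)c1ccc(N(C)C)cc1)c1ccc(Cl)cc1`, which in this assay gives 150%. For the measured compounds named here, that pair is the only step recorded: a number 12 percentage points lower from compound 1 to compound 2 (beyond the scatter).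

Compound 3, `Cc1cccc(Cl)c1C(=O)NC(CCN(C)C)c1ccc(Cl)cc1`, has not yet been measured. Compared with compound 1 the difference is 2-chloro-6-methylphenyl in place of 4-methoxyphenyl on a carbonyl carbon. The measured step from compound 1 to compound 2 alters a substituent on the same aromatic ring, whereas the step to compound 3 exchanges the whole acyl aromatic group; it therefore bears only loosely on the new compound, showing that a change on this ring moved the maximal response modestly and downward. Going by the values given here, no measured pair covers a 2-chloro-6-methylphenyl group. The step expected from compound 1 to compound 3 in this assay is a number 17 percentage points lower from compound 1 to compound 3 (beyond the scatter), a modest decrease, with wide uncertainty. Compound 3 is therefore estimated at 145%, within a range from 105% to 175%.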

Compound 3, largest response reached (reported as efficacy), in percent of the reference or control that the assay uses: 105%
Estimate against measurement, compound 3: 40 percentage points above; the range from low to high includes it.
By their numbers in this assay, from the lowest: compound 3; then compound 2; then compound 1.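

In this assay, for the compounds shown here, the acyl aromatic group proves to matter far more than the earlier pair suggested: replacing 4-methoxyphenyl with 2-chloro-6-methylphenyl on a carbonyl carbon gives a number 57 percentage points lower from compound 1 to compound 3 (beyond the scatter) and is a large change, whereas the only earlier step, a number 12 percentage points lower from compound 1 to compound 2 (beyond the scatter), was modest. The size of the new drop does not follow from the counts of heavy atoms or rings, as the leaving and entering groups have the same number of heavy atoms and each has one six-membered aromatic ring of carbon only; they differ in that the entering group has chlorine in place of oxygen and no hydrogen-bond acceptor. Nothing available explains why the maximal response falls so far with this exchange.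

The compounds shown leave open whether the chlorine, the methyl or the two together go with the lower number, and a 2-chlorophenyl or a 2-methylphenyl group on the same carbonyl would separate those cases. They also leave open how an unsubstituted phenyl or a pyridine ring would compare with the 4-methoxyphenyl of compound 1.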